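Benzylamide variant of the dihydroxy-acid series

The source may report more compounds than this note shows. Statements on the series, on what has been measured and on what is new or still open speak of the compounds shown alone.

In a functional assay on L6 cells (Rattus norvegicus) for inhibition (on this read-out lower numbers stand for stronger inhibition and higher numbers for weaker inhibition), compound 2 `CC(C)c1c(C(=O)NCc2cccc(F)c2F)nn(-c2ccc(F)cc2)c1OC[C@@H](O)C[C@@H](O)CC(=O)O` gives 120 nM, the lower of the two numbers at hand. Compound 1 `CC(C)c1c(C(=O)N(C)Cc2cccc(F)c2)nn(-c2ccc(F)cc2)c1CC[C@@H](O)C[C@@H](O)CC(=O)O` gives 1900 nM in this assay, and the gap to compound 2 lies beyond the scatter. Compound 3 `COc1cccc(CNC(=O)c2nn(-c3ccc(F)cc3)c(OC[C@@H](O)C[C@@H](O)CC(=O)O)c2C(C)C)c1` has not been measured; it differs from compound 2 by 3-methoxyphenyl in place of 2,3-difluorophenyl on a saturated chain carbon bound to an amide-type nitrogen. Among the measured compounds shown here, no measured pair shows this exchange, so its effect is unknown. The expected step in this assay is a 1.7-fold higher number from compound 2 to compound 3 (0.22 log units; within the scatter), a small move toward weaker inhibition, not clearly beyond the scatter. Compound 3 is estimated at 200 nM, within 60 nM to 700 nM.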

Compound 3, half-maximal inhibitory concentration: 8750 nM
Compound 3: middle estimate off by 44-fold (1.64 log units), on the low side, and the stated range ends below it.
By their numbers in this assay, from the lowest: compound 2; then compound 1; then compound 3.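

The (2,3-difluorobenzyl)carbamoyl position is sensitive to its aryl substituents: in this assay the exchange of 2,3-difluorobenzyl for 3-methoxybenzyl gives a 73-fold higher number from compound 2 to compound 3 (1.86 log units; beyond the scatter) and so counts as a large loss of inhibition. This single exchange keeps the ring and heavy-atom count of the group unchanged, so these two counts alone do not preserve inhibition here. No measurement shown bears on the cause of this step.

Going by these compounds, the exchange removes both fluorines and adds a methoxy group in one move, and the separate contribution of each stays open. Also open, on these data alone, is how an unsubstituted benzyl or a 3-chlorobenzyl group would read at this position.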